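This account rests on a few compounds, and the source may have more. Where it says the series, first, only, none or still open, it means among the compounds named here.

Measured so far in a functional assay on A549 cells (Homo sapiens) for antiproliferative activity, read by MTT assay, with a stated time of 48 h; on this read-out lower numbers stand for stronger inhibition and higher numbers for weaker inhibition:
Compound 1 `CN(C)CCCn1c(N)c(-c2nc3ccccc3s2)c2nc(C#N)c(C#N)nc21`: 8870 nM
Compound 2 `CN(C)CCn1c(N)c(-c2nc3ccccc3n2C)c2nc(C#N)c(C#N)nc21`: > 50000 nM

Compound 2 stands at the end of the measurable range, and its > 50000 nM is a limit of the assay and not a number. Compound 3 `CN(C)CCCn1c(N)c(-c2nc3ccccc3n2C)c2nc(C#N)c(C#N)nc21` differs from compound 2 in the side chain alone: (dimethylamino)methyl in place of dimethylamino on a saturated chain carbon, two bonds along the chain from an aromatic nitrogen. The change places (dimethylamino)methyl in place of dimethylamino on a saturated chain carbon, two bonds along the chain from an aromatic nitrogen, so that 2-(dimethylamino)ethyl becomes 3-(dimethylamino)propyl.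

Among the compounds with values here, no measured pair isolates this change, so its size cannot be read directly from the data. Within the data shown here, the only guide is compound 1, which carries the same 3-(dimethylamino)propyl chain, differs elsewhere, and gives 8870 nM. On that basis, a shift towards stronger inhibition in this assay is expected, though compound 3 may remain weak and could still reach the limit. The expected size of the change is an at least 2.5-fold lower number from compound 2 to compound 3 (0.39 log units; beyond the scatter). For compound 3 the estimated value is 20000 nM, with an expected range from 7000 nM to 50000 nM.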

Compound 3, half-maximal inhibitory concentration: 11700 nM
Beside the measured number, compound 3's estimate is 1.7-fold (0.23 log units) above it; low and high end bracket the measured number.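

In this assay, within the data shown here, the pair of compound 2 and compound 3 isolates the change from 2-(dimethylamino)ethyl to 3-(dimethylamino)propyl for the first time, and the longer chain gives an at least 4.2-fold lower number from compound 2 to compound 3 (0.63 log units; beyond the scatter), which brings the series on the 1-methyl-1H-benzimidazol-2-yl side back into the measurable range. The full size of this step cannot be read, since the reading for compound 2 is a limit of the assay and not a number: the limit of > 50000 nM in this assay, at which 1 of the 3 values shown sits. With the 3-(dimethylamino)propyl chain held constant, 1-methyl-1H-benzimidazol-2-yl in place of 1,3-benzothiazol-2-yl on an aromatic carbon gives a 1.3-fold higher number from compound 1 to compound 3 (0.12 log units; within the scatter), so these two groups cannot be told apart in this read-out.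

The compounds shown leave open whether a longer chain, such as 4-(dimethylamino)butyl, would carry the gain further or lose it, and whether the 2-(dimethylamino)ethyl chain would also reach the limit on the 1,3-benzothiazol-2-yl compound. They also leave open whether the dimethylamino end itself matters, as a primary amine, a morpholine or a carboxylic acid at the end of the same chain would show.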